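A few compounds are considered here, and "the series" means these few. Any claim that something is new, unique, unknown or untested is made for them only; others in the source may bear on it.

Of the compounds shown here, three sharing one core have been tested in a functional assay on BXPC-3 cells (Homo sapiens) for inhibition, read by MTT assay, with a stated time of 72 h; a higher number here means a weaker inhibitor of growth, a lower number a stronger inhibitor of growth. Compound 1 `CC(C)(C)c1ccc(CNCCCNS(=O)(=O)c2cc(C(F)(F)F)cc(C(F)(F)F)c2)cc1` gives 1400 nM. Compound 2 `COc1ccc(CNCCCNS(=O)(=O)c2cc(C(F)(F)F)cc(C(F)(F)F)c2)cc1OC` gives 13000 nM. Compound 3 `O=S(=O)(NCCCNCC1COc2ccccc2O1)c1cc(C(F)(F)F)cc(C(F)(F)F)c1` gives 1200 nM, the lowest of the three numbers, though its gap to compound 1, a 1.2-fold lower number from compound 1 to compound 3 (0.07 log units; within the scatter), is within the scatter, while its gap to compound 2, an 11-fold lower number from compound 2 to compound 3 (1.03 log units; beyond the scatter), is beyond it.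

Compound 4 `O=S(=O)(NCCCNCc1ccc(C(F)(F)F)cc1)c1cc(C(F)(F)F)cc(C(F)(F)F)c1` differs from compound 3 in one place: 4-(trifluoromethyl)phenyl in place of 2,3-dihydro-1,4-benzodioxin-2-yl on a saturated chain carbon bound to an amine nitrogen. Among the measured compounds shown here, no measured step swaps exactly these two groups. The closest guide is the step from compound 1, which also carries a substituted benzene ring at that position, to compound 3, a 1.2-fold lower number from compound 1 to compound 3 (0.07 log units; within the scatter), which was within the scatter. For the measured compounds named here, the only step beyond the scatter, an 11-fold lower number from compound 2 to compound 3 (1.03 log units; beyond the scatter), involved a benzene ring bearing two methoxy groups, unlike the group entering compound 4. Compound 4 is therefore expected to land near compound 3, with the step of a 1.3-fold higher number from compound 3 to compound 4 (0.10 log units; within the scatter) judged as none beyond the scatter. The estimated value for compound 4 in this assay is 1500 nM, expected to fall from 600 nM to 4500 nM.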

Compound 4, concentration for 50% growth inhibition: 1700 nM
Compound 4: middle estimate off by 1.1-fold (0.05 log units), on the low side; the measured number falls inside the stated range.
By their numbers in this assay, from the lowest: compounds 3, 1 and 4 (each within the scatter of the next); then compound 2.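

In this assay the move to 4-(trifluoromethyl)phenyl gives a 1.4-fold higher number from compound 3 to compound 4 (0.15 log units; within the scatter) and a 1.2-fold higher number from compound 1 to compound 4 (0.08 log units; within the scatter), so at this saturated chain carbon bound to an amine nitrogen three quite different groups now read alike. Against that pattern stands only compound 2, and a 7.6-fold lower number from compound 2 to compound 4 (0.88 log units; beyond the scatter) shows that its 3,4-dimethoxyphenyl group remains the weak outlier, now set apart from a third group and not just two. Nothing measured here bears on why that group stands apart.

The compounds shown leave open whether one methoxy group on the benzene ring would be enough to weaken growth inhibition, or whether both are needed. They also leave open how an unsubstituted phenyl or a pyridine ring would read at this position.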